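Replacing the phenyl tail of compound 1 by 2-hydroxyethyl

A few compounds are considered here, and "the series" means these few. Any claim that something is new, unique, unknown or untested is made for them only; others in the source may bear on it.

Among the compounds with values here, compound 1 `CN1CCN(c2nc3ccccc3n2CCOc2ccccc2)CC1` gives 6.9 nM in a functional assay on ileum for inhibition of histamine H1 receptor (Cavia porcellus) (a higher number here means a weaker inhibitor, a lower number a stronger inhibitor), the lowest of the two numbers measured so far; compound 2 `CN1CCCN(c2nc3ccccc3n2CCOc2ccccc2)CC1` gives 9.1 nM, and the step of a 1.3-fold higher number from compound 1 to compound 2 (0.12 log units; within the scatter) stays within the scatter. Compound 3 `CN1CCN(c2nc3ccccc3n2CCOCCO)CC1` differs from compound 1 at another place: 2-hydroxyethyl in place of phenyl on an oxygen on a saturated carbon. Within the data shown here, the only measured step, from compound 1 to compound 2, alters the group on an aromatic carbon and leaves the phenoxy tail untouched, so nothing measured bears on the phenoxy to 2-hydroxyethoxy change. A weaker inhibitor is nevertheless expected for compound 3, estimated at 60 nM with a range of 10 nM to 400 nM. The expected step is an 8.7-fold higher number from compound 1 to compound 3 (0.94 log units; beyond the scatter).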

Compound 3, half-maximal inhibitory concentration: 42 nM
Compound 3: the middle estimate sits 1.4-fold (0.15 log units) above what was measured; the range from low to high includes it.
By their numbers in this assay, from the lowest: compounds 1 and 2 (each within the scatter of the next); then compound 3.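

In this assay the exchange of phenyl for 2-hydroxyethyl on this oxygen gives a 6.1-fold higher number from compound 1 to compound 3 (0.78 log units; beyond the scatter) and so, unlike the step on the aromatic carbon, moves the number beyond the scatter. The aromatic ring is not indispensable here: without it compound 3 still gives 42 nM and the step stays modest. Nothing available accounts for the size of this step.

On these data alone, whether the step follows the loss of the ring or the arrival of the hydroxyl stays open. A cyclohexyl or a 2-methoxyethyl on this oxygen would separate the two.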